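The compounds below may be only part of what the source reports. "The series", "measured", "known", "first", "only" and "open" are said of these compounds alone.

Of the compounds shown here, three have so far been measured in an assay on isolated protein for inhibition of serine protease 1 (Bos taurus); on this read-out lower numbers stand for stronger inhibition and higher numbers for weaker inhibition. Compound 1 `Cc1c(F)c(Oc2cccc(C(=N)N)c2)nc(Oc2cccc(N(C)C)c2)c1F` gives 1900 nM, compound 2 `CN(C)C(=O)c1cccc(Oc2cc(C(=O)O)cc(Oc3cc(C(=N)N)ccc3O)n2)c1` gives 300 nM, and compound 3 `Cn1ccnc1-c1cccc(Oc2cc(C(=O)O)cc(Oc3cc(C(=N)N)ccc3O)n2)c1` gives 660 nM, the second highest of the three numbers; its nearest neighbour is compound 2 and its furthest is compound 1. Compound 4 `N=C(N)c1ccc(O)c(Oc2cc(C(=O)O)cc(Oc3cccc(-n4ccnc4)c3)n2)c1` has not yet been measured. It differs from compound 3 in one place: 1H-imidazol-1-yl in place of 1-methyl-1H-imidazol-2-yl on an aromatic carbon. Going by the values given here, only one measured step concerns the same aromatic carbon, a 2.2-fold higher number from compound 2 to compound 3 (0.34 log units; beyond the scatter), a modest shift. That step swapped in a different kind of group, so it offers weak guidance for exchanging 1-methyl-1H-imidazol-2-yl for 1H-imidazol-1-yl. Compound 4 is therefore expected to show a step of a 1.1-fold lower number from compound 3 to compound 4 (0.04 log units; within the scatter), essentially within the scatter. For compound 4 the estimate in this assay is 600 nM, with a range from 250 nM to 1500 nM.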

Compound 4, inhibition constant: 1200 nM
For compound 4 the middle estimate is 2.0-fold (0.30 log units) below the measured one; low and high end bracket the measured number.
By their numbers in this assay, from the lowest: compound 2; then compounds 3, 4 and 1 (each within the scatter of the next, the first and the last beyond it).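

Swapping 1-methyl-1H-imidazol-2-yl for 1H-imidazol-1-yl on this aromatic carbon gives a 1.8-fold higher number from compound 3 to compound 4 (0.26 log units; within the scatter) in this assay and so does not separate these two rings. Replacing dimethylcarbamoyl with 1H-imidazol-1-yl gives a 4.0-fold higher number from compound 2 to compound 4 (0.60 log units; beyond the scatter) and shows that both rings tested here leave a higher number than dimethylcarbamoyl does. Nothing available explains these differences. Still open, on these data alone, is whether a primary amide, a methyl ester or an aminomethyl group at this position would match or improve on dimethylcarbamoyl.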